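Replacing a Benzyl Group with a Pyrrolidinyloxy Group

The compounds below may be only part of what the source reports. "The series", "measured", "known", "first", "only" and "open" are said of these compounds alone.

Measured so far in an assay on isolated protein for inhibition of Myeloperoxidase (Homo sapiens), with a stated time of 10 min; on this read-out higher numbers stand for weaker inhibition and lower numbers for stronger inhibition:
compound 1, `Nc1cc(Cc2ccn(Cc3ccc4c(c3)CCNC4)n2)c2nn[nH]c2n1`: 58 nM
compound 2, `Nc1cc(Cc2ccn(Cc3ccc4ccccc4c3)n2)c2nn[nH]c2n1`: 52 nM
compound 3, `Nc1cc(Cc2ccn(Cc3cccc(Cc4ccccc4)c3)n2)c2nn[nH]c2n1`: 39 nM

All three share the same core and differ only in the group hanging from it. Compound 3 has the lowest of the three numbers, yet its nearest neighbour, compound 2, lies within the usual scatter of repeated measurements, and so does compound 1. On these numbers the three compounds cannot be told apart.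

Compound 4, `Nc1cc(Cc2ccn(Cc3cccc(O[C@H]4CCNC4)c3)n2)c2nn[nH]c2n1`, keeps everything else and differs from compound 3 in one place: (pyrrolidin-3-yl)oxy in place of benzyl on an aromatic carbon. Within the data shown here, no pair of measured compounds differing in a single place is available, so no measured step can guide the size of this change. The three measured compounds carry quite different side groups and still give nearly the same numbers, which suggests that this part of the molecule tolerates variation. The expectation is therefore a step of no size beyond the scatter in this assay, in either direction. Compound 4 is expected to give about 55 nM, with a range from 25 nM to 130 nM. This estimate means a step of a 1.4-fold higher number from compound 3 to compound 4 (0.15 log units; within the scatter) that is expected to stay within the scatter.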

Compound 4, half-maximal inhibitory concentration: 46 nM
The estimate for compound 4 lay 1.2-fold (0.08 log units) above the measured number, within the range that was stated.
By their numbers in this assay, from the lowest: compounds 3, 4, 2 and 1 (each within the scatter of the next).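

In this assay, among these compounds, the one comparison of compounds differing in a single place gives a 1.2-fold higher number from compound 3 to compound 4 (0.07 log units; within the scatter), so putting (pyrrolidin-3-yl)oxy in place of benzyl on this aromatic carbon produces no step that can be told from the scatter. Among the compounds shown here, this is the first direct reading at this position, and it covers a substantial exchange: a six-membered aromatic ring of carbon only, with no hydrogen-bond donors or acceptors, gives way to a five-membered non-aromatic ring with a hetero atom, linked through oxygen and carrying both donor and acceptor capacity. Nothing available explains why the number holds steady across this exchange.

One exchange at one position leaves open how far this tolerance extends, and whether a group of a different kind on the same aromatic carbon, such as a carboxylic acid, a primary amine or a longer carbon chain, would also stay within the scatter. It also leaves open whether the mirror-image form of the (pyrrolidin-3-yl)oxy group would give a similar number, since its defined stereocentre is represented here in one form only.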